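The compounds below may be only part of what the source reports. "The series", "measured", "known", "first", "only" and "open" are said of these compounds alone.

Compound 1 `O=C(CCCCCCc1cccc(F)c1)N1CCCC1` and compound 2 `O=C(CCCCCCc1ccc(F)cc1)N1CCCC1` are built from the same atoms joined differently; the difference between the two cores is not broken down here. In an assay on HEK293 cells for inhibition of N-acylethanolamine-hydrolyzing acid amidase (Rattus norvegicus), read by LC-MS, with a stated time of 30 min (on this read-out lower numbers stand for stronger inhibition and higher numbers for weaker inhibition), compound 1 gives 7300 nM, and in this assay compound 2 gives 8000 nM, the two numbers lying within the scatter of each other. Compound 3 `O=C(CCCCCCc1cccc(Cl)c1)N1CCCC1` carries the change (chloro in place of fluoro on an aromatic carbon), and in this assay compound 3 gives 3700 nM, so that a 2.0-fold lower number from compound 1 to compound 3 (0.30 log units; within the scatter). Compound 4 `O=C(CCCCCCc1ccc(Cl)cc1)N1CCCC1`, still unmeasured, carries the same kind of change, (chloro in place of fluoro on an aromatic carbon), though here the place is para to a large group rather than meta to it. From compound 2 to compound 4 a step of a 2.0-fold lower number from compound 2 to compound 4 (0.30 log units; within the scatter) is expected because a 2.0-fold lower number from compound 1 to compound 3 (0.30 log units; within the scatter). For compound 4 in this assay an estimated value of 4000 nM is expected.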

Compound 4, half-maximal inhibitory concentration: 34500 nM
The estimate for compound 4 lay 8.6-fold (0.94 log units) below the measured number; the whole stated range lies below it.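

In this assay, chloro in place of fluoro on an aromatic carbon para to a large group gives a 4.3-fold higher number from compound 2 to compound 4 (0.63 log units; beyond the scatter), so the change does not carry from the core of compound 1 to the core of compound 2 with the same direction or size: the same change on two cores in this assay, a 2.0-fold lower number (0.30 log units; within the scatter) from compound 1 to compound 3 and a 4.3-fold higher number (0.63 log units; beyond the scatter) from compound 2 to compound 4, 8.5-fold (0.93 log units) apart, beyond the scatter of two such steps

Within these compounds, the step on one core therefore did not predict the step on the other. This does not show why the two steps differ, and two cores say nothing about how the change behaves on any others.

The compounds shown leave open where a bromo or methoxy group on the same aromatic carbon would stand relative to compound 2 and compound 4. They also leave open whether the two steps would still differ with a shorter or longer chain.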